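A few compounds are considered here, and "the series" means these few. Any claim that something is new, unique, unknown or untested is made for them only; others in the source may bear on it.

Compound 1, `COc1cccc(-c2nn(-c3ccccc3)cc2C(Nc2nc3ccccc3s2)c2c(O)ccc3ccccc23)c1`, gives 24800 nM in a functional assay on A549 cells (Homo sapiens) for antiproliferative activity, read by MTT assay, with a stated time of 48 h; on this read-out higher numbers stand for weaker inhibition and lower numbers for stronger inhibition.
Compound 2, `Oc1ccc2ccccc2c1C(Nc1nc2ccccc2s1)c1cn(-c2ccccc2)nc1-c1cccc(Cl)c1`, gives 20400 nM in this assay.
Compound 3, `COc1ccc2nc(NC(c3cn(-c4ccccc4)nc3-c3ccc(F)cc3)c3c(O)ccc4ccccc34)sc2c1`, gives 33600 nM in this assay.

All three compounds share a large common framework and sit close together in this assay; the gaps among them fall within the usual scatter, so none can be called stronger or weaker than another. Compound 1 and compound 2 differ in a single spot, (chloro in place of methoxy on an aromatic carbon), and that change made the step of a 1.2-fold lower number from compound 1 to compound 2 (0.08 log units; within the scatter).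

Compound 3 carries a different core from compound 1; the difference between the two cores is not broken down here. Compound 4, `Oc1ccc2ccccc2c1C(Nc1nc2ccc(Cl)cc2s1)c1cn(-c2ccccc2)nc1-c1ccc(F)cc1`, has not yet been measured. It differs from compound 3 by chloro in place of methoxy on an aromatic carbon. The group that leaves and the group that enters are the same as in the pair of compound 1 and compound 2, but the surroundings differ: in the earlier pair the place is meta to a large group on a lone ring, whereas here it is part of a fused system of two rings, meta and para to a fused ring. It is therefore the same kind of change, not the same change.

Among the measured compounds shown here, since the one measured example of this kind of change, a 1.2-fold lower number from compound 1 to compound 2 (0.08 log units; within the scatter), stayed within the scatter, a similarly small step is expected, a 1.2-fold lower number from compound 3 to compound 4 (0.08 log units; within the scatter). Compound 4 is estimated at 28000 nM, with a likely range from 12000 nM to 70000 nM.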

Compound 4, half-maximal inhibitory concentration: 32200 nM
The estimate for compound 4 lay 1.2-fold (0.06 log units) below the measured number, and the stated range covers the measured number.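

In this assay, putting chloro in place of methoxy on the ring of the fused system gave a 1.0-fold lower number from compound 3 to compound 4 (0.02 log units; within the scatter), so once more the swap left no change that can be told apart from the noise of repeated measurements. Set side by side, the two steps agree with each other: the same change on two cores in this assay, a 1.2-fold lower number (0.08 log units; within the scatter) from compound 1 to compound 2 and a 1.0-fold lower number (0.02 log units; within the scatter) from compound 3 to compound 4, 1.2-fold (0.07 log units) apart, within the scatter of two such steps. Among the compounds shown here, this shows that, on these two cores and at these two places, one on a lone ring and one in a fused system of two rings, the swap behaved alike and left the number where it was, but it rests on only two pairs, and two steps this small cannot reveal whether the core would matter for a swap that moves the number by more, nor do they show that the two groups would be interchangeable on any other core or in any other test.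

The compounds shown leave open whether a different group at these places, such as a plain hydrogen, an amine, a carboxylic acid or a longer chain like butoxy, would move the number beyond the scatter. They also leave open whether the swap of methoxy for chloro would stay this quiet at other places on the shared framework.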